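This account rests on a few compounds, and the source may have more. Where it says the series, first, only, none or still open, it means among the compounds named here.

Two compounds define the ground here. Compound 1 `O=C(Nc1cccc(-n2cc(-c3ccncc3)c(-c3ccc(Cl)c(O)c3)n2)c1)Nc1ccc(Cl)c(Cl)c1`, a urea, gives 2740 nM in a functional assay on NCI/ADR-RES cells (Homo sapiens) for inhibition, read by sulforhodamine B assay, with a stated time of 48 h; a higher number here means a weaker inhibitor of growth, a lower number a stronger inhibitor of growth. Compound 2 `COc1cc(-c2nn(-c3cccc(NC(=O)c4ccc(Cl)c(C(F)(F)F)c4)c3)cc2-c2ccncc2)ccc1Cl`, an amide, gives 1290 nM in the same assay. On these two numbers compound 2 stands lowest, and its gap to compound 1 lies beyond the usual scatter, so compound 2 is the stronger growth inhibitor of the pair. Within the data shown here, no single-point step between measured compounds is available, so nothing measured yet tells how a change on the amide aryl ring moves the number.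

Compound 3 `COc1cc(-c2nn(-c3cccc(NC(=O)c4cccc(C(F)(F)F)c4)c3)cc2-c2ccncc2)ccc1Cl` is the next compound, not yet measured. It differs from compound 2 in one place: hydrogen in place of chloro on an aromatic carbon. Only the chloro is lost; the trifluoromethyl group and the rest of the shared core stay as they are.

The account expects the step from compound 2 to compound 3 to be a 1.6-fold higher number from compound 2 to compound 3 (0.19 log units; within the scatter), a modest move toward a weaker growth inhibitor, of a size close to the scatter. Compound 3 is therefore estimated at 2000 nM, within a range from 900 nM to 4500 nM.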

Compound 3, concentration for 50% growth inhibition: 1090 nM
Compound 3: the middle estimate sits 1.8-fold (0.26 log units) above what was measured, and the stated range covers the measured number.
By their numbers in this assay, from the lowest: compounds 3 and 2 (each within the scatter of the next); then compound 1.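

Among these compounds, the first single-point step comes from this assay and reads a 1.2-fold lower number from compound 2 to compound 3 (0.07 log units; within the scatter) on going from 4-chloro-3-(trifluoromethyl)phenyl to 3-(trifluoromethyl)phenyl. On this evidence, the chloro on this aromatic carbon, ortho to the trifluoromethyl group and para to a large group, can give way to hydrogen without a change that stands out from the scatter, so this one heavy atom is not needed to hold the growth inhibition at the level seen with the amide pair. No supporting measurement bears on why the position tolerates this change.

The compounds shown do not tell whether this tolerance is specific to hydrogen and chloro, since a fluoro, a nitrile or an amine on the same carbon could read quite differently. They also leave open what the trifluoromethyl group contributes when it is itself replaced by hydrogen or a methyl group, and whether the same chloro-to-hydrogen step would read alike on a urea such as compound 1.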